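A Piperidine Swap on a Thiocarbonyl Carbon

The compounds below may be only part of what the source reports. "The series", "measured", "known", "first", "only" and "open" are said of these compounds alone.

In a functional assay on MCF7 cells (Homo sapiens) for antiproliferative activity, read by MTT assay, with a stated time of 96 h (a lower number here means a stronger inhibitor, a higher number a weaker inhibitor), compound 1 `O=C1CC2(CCCCC2)Oc2c1ccc1ccccc21` gives 10700 nM as its reading. Alongside it, compound 2 `S=C(N/N=C1\CC2(CCCCC2)Oc2c1ccc1ccccc21)N1CCNCC1` gives 14200 nM as its reading. Going by the values given here, these two values lie within the scatter of each other, so compound 2 stands level with compound 1 on the only numbers available. Compound 3 `S=C(CN1CCCCC1)N/N=C1\CC2(CCCCC2)Oc2c1ccc1ccccc21` keeps the shared core and carries (piperidin-1-yl)methyl in place of piperazin-1-yl on a thiocarbonyl carbon. Among the compounds with values here, no measured step shows what such an exchange does, so the expectation rests on the two values alone. With compound 2 at 14200 nM as the closest reference, no step beyond the scatter is expected in this assay for this change. The estimated step (a 1.3-fold lower number from compound 2 to compound 3 (0.11 log units; within the scatter)) is therefore small. Compound 3 is expected at 11000 nM (estimated range 4000 nM to 30000 nM).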

Compound 3, half-maximal inhibitory concentration: 11700 nM
Beside the measured number, compound 3's estimate is 1.1-fold (0.03 log units) below it; the range from low to high includes it.
By their numbers in this assay, from the lowest: compounds 1, 3 and 2 (each within the scatter of the next).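

On the thiocarbonyl carbon, (piperidin-1-yl)methyl in place of piperazin-1-yl gives a 1.2-fold lower number from compound 2 to compound 3 (0.08 log units; within the scatter) in this assay. This first step at this position shows that one six-membered non-aromatic ring can replace another here, with 0 hydrogen-bond donors entering where 1 leaves and with the added heavy atom in the entering group, without a reading outside the scatter. No supporting measurement bears on what lies behind this result.

The compounds shown leave open whether a morpholine ring, a carboxylic acid or a longer chain ending in piperidin-1-yl on the thiocarbonyl carbon would move the reading beyond the scatter. They also leave open whether a fluorine or a methoxy group on the shared core would do so.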